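A Sulfonyl Swap on a Core at the Limit

The source may hold more compounds than are shown below. What is called first, only, known or untested is meant among the compounds shown, and "the series" means these compounds.

Compound 1 `C=CCNC(=O)n1c(-c2ccc(OC)cc2)cc(=O)c2c(OC)cc(OC)cc21` was examined in a functional assay on HepG2 cells (Homo sapiens) for antiproliferative activity, with a stated time of 72 h; on this read-out lower numbers stand for an effect already at smaller amounts and higher numbers for an effect only at larger amounts of compound. In this assay compound 1 gives > 20000 nM, a limit of the assay rather than a measured number. Two related compounds share this outcome. Compound 2 `COc1ccc(-c2c(Br)c(=O)c3c(OC)cc(OC)cc3n2S(=O)(=O)c2ccc(OC)cc2)cc1` gives > 20000 nM in this assay, again a limit. Compound 3 `COC(=O)c1cc(=O)c2c(OC)cc(OC)cc2n1C` gives > 19000 nM in this assay, also a limit. All three values therefore sit at the edge of what the assay reports: the limit of > 20000 nM in this assay, at which 2 of the 3 values shown sit, and (the limit of > 19000 nM in this assay, at which 1 of the 3 values shown sits). For the measured compounds named here, compound 1 thus stands level with the other two, and no measured step between any pair of them can be drawn.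

Compound 4 `COc1ccc(-c2cc(=O)c3c(OC)cc(OC)cc3n2S(=O)(=O)c2ccc(C#N)cc2)cc1` is the next compound to be measured in this assay. It differs from compound 1 in one place: (4-cyanophenyl)sulfonyl in place of allylcarbamoyl on an aromatic nitrogen. No measured step of this kind exists among the compounds shown. Because compound 1 gives only the limit > 20000 nM in this assay, the step is expected to stay within the scatter, as a number no higher from compound 1 to compound 4 (the limit leaves the size open). Compound 4 is accordingly expected to give about 20000 nM in this assay, with a range from 6000 nM to 60000 nM, and most likely only a limit will be reported.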

Compound 4, half-maximal effective concentration: > 17200 nM
Compound 4: only a limit was reported; the forecaster's own chance of this, stated with the estimate: 75%; the middle value does not contradict the limit.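

Compound 1 and compound 4 both give only a limit in this assay, and the step between them cannot be read. The compounds shown leave open whether (4-cyanophenyl)sulfonyl or allylcarbamoyl on the aromatic nitrogen makes any difference to the effect on these cells, and at what concentration any compound on the shared core would give a measured value.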